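The source may hold more compounds than are shown below. What is called first, only, known or untested is meant among the compounds shown, and "the series" means these compounds.

Compound 3, `CC1=C(C(=O)Nc2ccc(F)cc2)C(c2ccc([N+](=O)[O-])cc2)N=C(SCc2ccccc2Cl)N1`, was assessed in a functional assay on the whole organism (artery, strain albino) with Rattus norvegicus as the target, with a stated time of 180 min, at a dose of 10 mg/kg by the oral route (on this read-out higher numbers stand for more inhibition at the one dose given (going by the name of the read-out) and lower numbers for less inhibition), and gave 12.4%. Compound 1, `COc1ccc(C2N=C(SCc3cccc(Cl)c3)NC(C)=C2C(=O)Nc2ccc(F)cc2)cc1OC`, gave 13.4% in this assay, a value lying within the usual scatter of that of compound 3. Compound 2, `CC1=C(C(=O)Nc2ccc(F)cc2)C(c2ccc([N+](=O)[O-])cc2)N=C(SCc2ccccc2)N1`, gave 23.7% in this assay, and the one single-site step recorded among these three, a number 11.3 percentage points lower from compound 2 to compound 3 (beyond the scatter), is the only change whose effect is known here. Compound 4, `CC1=C(C(=O)Nc2ccc(F)cc2)C(c2ccc([N+](=O)[O-])cc2)N=C(SCc2cccc(Cl)c2)N1`, differs from compound 3 by 3-chlorophenyl in place of 2-chlorophenyl on a saturated chain carbon bound to a sulfur. Among the measured compounds shown here, no recorded step moves a chlorine from one position of the benzyl ring to another; compound 1 carries the same 3-chlorobenzyl group as compound 4 but differs from compound 3 also in the aryl attached to the shared core, so it is not a single-site comparison. The step to compound 4 is therefore expected to be a number 1.6 percentage points higher from compound 3 to compound 4 (within the scatter), that is, no change beyond the scatter, and compound 4 is estimated to give 14% in this assay, between 4% and 26%.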

Compound 4, a percentage reported as inhibition, in the whole organism at one dose (the size of the read-out at that dose, not a potency): 11.9%
Beside the measured number, compound 4's estimate is 2.1 percentage points above it; the range from low to high includes it.
By their numbers in this assay, from the lowest: compounds 4, 3 and 1 (each within the scatter of the next); then compound 2.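

In this assay, 3-chlorophenyl in place of 2-chlorophenyl on a saturated chain carbon bound to a sulfur gives a number 0.5 percentage points lower from compound 3 to compound 4 (within the scatter) and so no distinction between the two chlorine placements. The chlorine step now stands for both placements, with a number 11.8 percentage points lower from compound 2 to compound 4 (beyond the scatter) alongside the earlier a number 11.3 percentage points lower from compound 2 to compound 3 (beyond the scatter) and thus a lower number with either chlorobenzyl group than with the unsubstituted benzyl group of compound 2. Among the compounds shown here, compound 4 also gives the first single-site reading of the aryl on the saturated ring carbon, where 4-nitrophenyl in place of 3,4-dimethoxyphenyl gives a number 1.5 percentage points lower from compound 1 to compound 4 (within the scatter) with the 3-chlorobenzyl group held fixed.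

Going by these compounds, how a 4-chlorobenzyl group, a 3-methoxybenzyl group or a phenethyl chain on the sulfur would read in this assay remains open. Nothing available here accounts for the lower numbers with chlorine.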